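Indole-diterpene esters: swapping methoxy for trifluoromethyl

The source may report more compounds than this note shows. Statements on the series, on what has been measured and on what is new or still open speak of the compounds shown alone.

Measured compounds:
Compound 1, `COC(=O)[C@@]1(C)CCC=C2[C@@H]1CC[C@@H](C)[C@]2(C)Cc1c(C)[nH]c2ccccc12`: 14000 nM
Compound 2, `COC(=O)[C@@]1(C)CCC=C2[C@@H]1CC[C@@H](C)[C@]2(C)Cc1c(C)[nH]c2ccc(OC)cc12`: 15000 nM

Both numbers come from a functional assay on SW1573 cells (Homo sapiens) for inhibition, read by sulforhodamine B assay, with a stated time of 48 h; a higher number here means a weaker inhibitor of growth, a lower number a stronger inhibitor of growth. Compound 2 stands highest of the two, though the gap to compound 1 is small: a 1.1-fold higher number from compound 1 to compound 2 (0.03 log units; within the scatter). So adding a methoxy group to the aromatic ring of compound 1 left the growth inhibition essentially unchanged.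

Compound 3, `COC(=O)[C@@]1(C)CCC=C2[C@@H]1CC[C@@H](C)[C@]2(C)Cc1c(C)[nH]c2ccc(C(F)(F)F)cc12`, has not yet been measured in this assay. It differs from compound 2 in one place: trifluoromethyl in place of methoxy on an aromatic carbon. The trifluoromethyl group sits on an aromatic carbon of a six-membered carbon-only ring within a fused two-ring system, at the same position the methoxy occupied.

For the measured compounds named here, no measured step involves a trifluoromethyl group, so the only guide is the single step from compound 1 to compound 2, which was within the scatter. On that basis no step beyond the scatter is expected, with wide uncertainty because of the untested group. For compound 3 the estimate in this assay is 12000 nM, with a range from 5000 nM to 30000 nM. This corresponds to an expected step of a 1.3-fold lower number from compound 2 to compound 3 (0.10 log units; within the scatter).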

Compound 3, concentration for 50% growth inhibition: 15000 nM
Compound 3: the middle estimate sits 1.3-fold (0.10 log units) below what was measured; measured number inside the range.
By their numbers in this assay, from the lowest: compounds 1, 2 and 3 (each within the scatter of the next).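

In this assay, trifluoromethyl in place of methoxy gives no change at the digits printed from compound 2 to compound 3 (within the scatter), and trifluoromethyl in place of hydrogen gives a 1.1-fold higher number from compound 1 to compound 3 (0.03 log units; within the scatter). This aromatic carbon has now carried hydrogen, methoxy and trifluoromethyl, and the three compounds lie within the scatter of one another, so exchanging these groups, which are built from different atoms, leaves growth inhibition in these cells effectively flat. No supporting information is available to explain why the result stays flat across these groups.

The compounds shown leave open whether this flat picture holds for very different groups on the same carbon, such as an amine or a carboxylic acid, since the three groups here cover only a small part of what could sit there. They also leave open how much the rest of the molecule contributes to growth inhibition, as the methyl ester on the shared core is the same throughout, and replacing it with a carboxylic acid or an amide would test that part directly.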